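Removing one methyl from the aryl group of compound 1

The source may hold more compounds than are shown below. What is called first, only, known or untested is meant among the compounds shown, and "the series" means these compounds.

Measured so far:
- compound 2, `Cc1ccccc1-c1nc(CN2CCC(C(=O)NCCCN3[C@H](C)CCC[C@@H]3C)CC2)c(C)o1`: 55.4 10^-6 cm/s
- compound 3, `Cc1cccc(Cl)c1-c1nc(CN2CCC(C(=O)NCCCN3CCCC(C)C3)CC2)c(C)o1`: 651 10^-6 cm/s

Compound 1, `Cc1ccc(C)c(-c2nc(CN3CCC(C(=O)NCCCN4C[C@H](C)C[C@H](C)C4)CC3)c(C)o2)c1`, has no result of its own in a physicochemical assay for permeability, using PAMPA (a higher number here means that the compound crosses the layer faster, a lower number that the compound crosses the layer more slowly), where compound 1 is recorded only as "not determined" (no result reported); it stands between the two measured compounds only by structure, not by number. Compound 4, `Cc1cccc(-c2nc(CN3CCC(C(=O)NCCCN4C[C@H](C)C[C@H](C)C4)CC3)c(C)o2)c1`, differs from compound 1 by hydrogen in place of methyl on an aromatic carbon. Among the measured compounds shown here, with no measured pair showing this change, its effect cannot be read from the data. In this assay compound 2 gives 55.4 10^-6 cm/s and compound 3 gives 651 10^-6 cm/s, so related compounds all cross readily. For compound 4 a value of 200 10^-6 cm/s is expected, with a likely range from 40 10^-6 cm/s to 900 10^-6 cm/s.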

Compound 4, apparent permeability: 279 10^-6 cm/s
Compound 4: the middle estimate sits 1.4-fold (0.14 log units) below what was measured; measured number inside the range.
By their numbers in this assay, from the lowest: compound 2; then compound 4; then compound 3.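

Compound 4 differs from compound 2 and from compound 3 in more than one place, so no new step can be read in this assay. What changing 2,5-dimethylphenyl to 3-methylphenyl does to the apparent permeability stays open, and no data shown explain these values.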